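A few compounds are considered here, and "the series" means these few. Any claim that something is new, unique, unknown or untested is made for them only; others in the source may bear on it.

Measured in a functional assay on BaF3 cells (Mus musculus) for antiproliferative activity, read by CCK-8 assay and cell counting, with a stated time of 76 h; on this read-out higher numbers stand for weaker inhibition and lower numbers for stronger inhibition:
- Compound 1 `COc1cc2nccc(Oc3ccc(Nc4nn(C)cc4C(=O)Nc4ccccc4)cc3)c2cc1C(N)=O`: > 10000 nM (a limit)
- Compound 2 `COc1cc2nccc(Oc3ccc(Nc4nn(C)cc4C(=O)NC4CCCCC4)cc3)c2cc1C(N)=O`: 4800 nM
- Compound 3 `COc1cc2nccc(Oc3ccc(Nc4nn(C)cc4C(=O)NCC(C)C)cc3)c2cc1C(N)=O`: > 10000 nM (a limit)

Compound 3, with isobutyl on the amide-type nitrogen, has no number, only a limit. It stands at the limit of > 10000 nM in this assay, at which 2 of the 3 values shown sit. Compound 2 is the only one of the three with a measured number.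

Compound 4 `COc1cc2nccc(Oc3ccc(Nc4nn(C)cc4C(=O)Nc4ccccc4F)cc3)c2cc1C(N)=O` differs from compound 3 in one place: 2-fluorophenyl in place of isobutyl on an amide-type nitrogen. This puts 2-fluorophenyl in place of isobutyl on an amide-type nitrogen.

Going by the values given here, three measured steps bear on this change. The nearest, isobutyl in place of phenyl, is a step that the two limits leave unreadable from compound 1 to compound 3. Cyclohexyl in place of phenyl gave an at least 2.0-fold lower number from compound 1 to compound 2 (0.31 log units; beyond the scatter), and isobutyl in place of cyclohexyl gave an at least 2.0-fold higher number from compound 2 to compound 3 (0.31 log units; beyond the scatter). Those two lie beyond the scatter, but both concern cyclohexyl, which compound 4 does not carry. Among the compounds with values here, no measured compound carries the fluorine.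

The expectation therefore leans on compound 1, which carries phenyl and whose > 10000 nM is a limit. No step beyond the scatter is expected in this assay, and a further limit is the likeliest report. The expected step is a number no higher from compound 3 to compound 4 (the limit leaves the size open). The estimate for compound 4 is 10000 nM, with an expected range from 3000 nM to 20000 nM.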

Compound 4, half-maximal inhibitory concentration: 1710 nM
Beside the measured number, compound 4's estimate is 5.8-fold (0.77 log units) above it; the whole stated range lies above it.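

In this assay, fluoro in place of hydrogen on an aromatic carbon gave an at least 5.8-fold lower number from compound 1 to compound 4 (0.76 log units; beyond the scatter), so a single change on the phenyl group at this amide-type nitrogen was enough to bring a measured number out of a compound that had shown only a limit. Going by these compounds alone, the same position also proved able to go past the only measured compound so far: 2-fluorophenyl in place of isobutyl gave an at least 5.8-fold lower number from compound 3 to compound 4 (0.76 log units; beyond the scatter), and 2-fluorophenyl in place of cyclohexyl gave a 2.8-fold lower number from compound 2 to compound 4 (0.45 log units; beyond the scatter), which means an aromatic ring here is not a bar to activity in itself, although compound 1, with plain phenyl, goes against any general preference for aromatic groups. Compound 1 and compound 3 remain limits rather than numbers: the limit of > 10000 nM in this assay, at which 2 of the 4 values shown sit.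

On these data alone, the step between compound 1 and compound 3 cannot be read, and the true size of each step starting from those two compounds stays open. Whether the gain belongs to fluorine alone is also open, since the compounds shown do not tell how a chloro or methoxy group on the phenyl ring, or a pyridine ring in its place, would compare.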